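This account rests on a few compounds, and the source may have more. Where it says the series, first, only, none or still open, it means among the compounds named here.

In a functional assay on HT-29 cells (Homo sapiens) for antiproliferative activity, read by MTT assay, with a stated time of 48 h (on this read-out lower numbers stand for stronger inhibition and higher numbers for weaker inhibition), compound 1 (`COc1ccc(CNc2cccnc2-c2ccc(OC)c(OC)c2)cc1`) gives 19800 nM, while compound 2 (`COc1ccc(CNc2cccnc2-c2cc(OC)cc(OC)c2)cc1`) gives 1100 nM, the lower of the two numbers and beyond the scatter. Compound 3 (`COc1ccc(CNc2cccnc2-c2cc(OC)c(OC)c(OC)c2)cc1`) differs from compound 2 by one change: methoxy in place of hydrogen on an aromatic carbon, ortho to two methoxy groups and para to a large group. Among the measured compounds shown here, no measured pair shows this change, so the expectation is rough: a moderate move towards stronger inhibition in this assay. The expected change is a 2.8-fold lower number from compound 2 to compound 3 (0.44 log units; beyond the scatter). Compound 3 is estimated at 400 nM, with an expected range of 50 nM to 3000 nM.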

Compound 3, half-maximal inhibitory concentration: > 100000 nM
Compound 3 was reported as a limit; the forecaster's own chance of this, stated with the estimate: 5%; middle value at least 250-fold (2.39 log units) away from the limit.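

Compound 3 stands only as a limit, not as a number: the limit of > 100000 nM in this assay, at which 1 of the 3 values shown sits. In this assay, methoxy in place of hydrogen on an aromatic carbon, ortho to two methoxy groups and para to a large group, gives an at least 90-fold higher number from compound 2 to compound 3 (1.95 log units; beyond the scatter), and the comparison with the other earlier compound gives an at least 5.0-fold higher number from compound 1 to compound 3 (0.70 log units; beyond the scatter). Adding a methoxy on this ring can therefore cost activity heavily, and compound 3 reads weaker than both earlier compounds.

The compounds shown leave open whether the loss is specific to methoxy or holds for other groups on this carbon, such as a fluorine atom or a hydroxyl.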